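The source may hold more compounds than are shown below. What is called first, only, known or untested is meant among the compounds shown, and "the series" means these compounds.

Compound 1 `Cc1cccc(Nc2nc3nonc3nc2Nc2cccc(C)c2)c1` carries a 3-methylphenyl group on each of the two nitrogens that flank the shared core. In an assay on mitochondria from L6 cells (Rattus norvegicus) for activation, with a stated time of 90 min (on this read-out higher numbers stand for an effect only at larger amounts of compound and lower numbers for an effect already at smaller amounts), compound 1 gives 2100 nM. Compound 2 `Cc1ccc(Nc2nc3nonc3nc2Nc2ccc(C)cc2)cc1` instead carries a 4-methylphenyl group on each of those nitrogens. In this assay compound 2 reaches only > 20000 nM, which is a limit of the assay and not a measured number. Compound 2 therefore stands at the limit of > 20000 nM in this assay, at which 1 of the 2 values shown sits, so all that is known is that its effect was not seen within the amounts tested. Compound 3 `Cc1ccc(Nc2nc3nonc3nc2Nc2ccccc2F)cc1` keeps one 4-methylphenyl group and changes the other: 2-fluorophenyl in place of 4-methylphenyl on a nitrogen on an aromatic ring. Among the compounds with values here, no comparable step between measured compounds is available, so the size and direction of this change can only be guessed. Since compound 1, with a different substitution pattern on both rings, gives 2100 nM, a shift of this kind can matter, and the step from compound 2 to compound 3 is expected to run toward lower numbers, by about an at least 2.5-fold lower number from compound 2 to compound 3 (0.39 log units; beyond the scatter). For compound 3 the estimate in this assay is 8000 nM, with a range from 1500 nM to 25000 nM.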

Compound 3, half-maximal effective concentration: 2100 nM
Compound 3: the middle estimate sits 3.8-fold (0.58 log units) above what was measured; measured number inside the range.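

In this assay, putting 2-fluorophenyl in place of 4-methylphenyl on one nitrogen gives an at least 9.5-fold lower number from compound 2 to compound 3 (0.97 log units; beyond the scatter), which shows that this position responds to the group it carries and that changing one of the two rings is enough to turn a compound with no measured effect into one with a measurable value. The value of compound 2, > 20000 nM, is a limit of the assay and not a number. The step can therefore be given only as a minimum, and its true size stays unknown because of where compound 2 stands: the limit of > 20000 nM in this assay, at which 1 of the 3 values shown sits.

The change from 4-methylphenyl to 2-fluorophenyl removes a methyl group, adds a fluorine and alters the place of the ring substituent all at once, so the compounds shown leave open which of these matters for the step. On these data alone, a 2-methylphenyl or a 4-fluorophenyl group at this position would help separate these factors, while a plain phenyl group would show the effect of having no ring substituent, and it also remains open whether the second ring responds in the same way.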